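The source may hold more compounds than are shown below. What is called first, only, known or untested is meant among the compounds shown, and "the series" means these compounds.

Among the compounds with values here, in a functional assay on MCF7 cells (Homo sapiens) for inhibition, read by MTT assay (on this read-out lower numbers stand for stronger inhibition of growth and higher numbers for weaker inhibition of growth), compound 2 (`COc1cc2oc(-c3cccc(NC(=O)c4ccc(Cl)cc4)c3)cc(=O)c2c(OC)c1OC`) gives 8780 nM and holds the lower of the two numbers so far. Compound 1 (`COc1cc2oc(-c3cccc(NC(=O)c4ccccc4Br)c3)cc(=O)c2c(OC)c1OC`) stands higher at 55000 nM on this read-out. Compound 3 (`COc1cc2oc(-c3cccc(NC(=O)c4ccc([N+](=O)[O-])cc4)c3)cc(=O)c2c(OC)c1OC`) is not yet measured and differs from compound 2 by nitro in place of chloro on an aromatic carbon in one place: nitro in place of chloro on an aromatic carbon. Within the data shown here, the one measured step (a 6.3-fold lower number from compound 1 to compound 2 (0.80 log units; beyond the scatter)) swaps 2-bromophenyl for 4-chlorophenyl and does not test nitro, so no step beyond the scatter is expected in this assay for compound 3, and no direction is favoured. The estimated step (a 1.1-fold lower number from compound 2 to compound 3 (0.04 log units; within the scatter)) therefore stays small. For compound 3 the estimate is 8000 nM (expected range 2500 nM to 28000 nM).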

Compound 3, concentration for 50% growth inhibition: 20100 nM
Compound 3: the middle estimate sits 2.5-fold (0.40 log units) below what was measured, and the stated range covers the measured number.
By their numbers in this assay, from the lowest: compound 2; then compound 3; then compound 1.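

In this assay nitro in place of chloro on this aromatic carbon gives a 2.3-fold higher number from compound 2 to compound 3 (0.36 log units; beyond the scatter), so this position responds to the group placed on it, with chloro ahead of nitro. The 4-nitrophenyl amide still improves on the 2-bromophenyl amide, giving a 2.7-fold lower number from compound 1 to compound 3 (0.44 log units; beyond the scatter), though by less than 4-chlorophenyl does. Nothing available explains the gap between chloro and nitro.

As far as these compounds go, how an amine, a hydroxyl group or a carboxylic acid would read at this same carbon remains open. Whether the bromo or the position accounts for the high number of compound 1 also stays unresolved.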